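A few compounds are considered here, and "the series" means these few. Any claim that something is new, unique, unknown or untested is made for them only; others in the source may bear on it.

Measured compounds:
- compound 1, `Clc1ccc2[nH]c(SCc3ccccc3CCc3ccccc3)nc2c1`, 47%
- compound 2, `c1ccc(CCc2ccccc2CSc2ncc[nH]2)cc1`, 19%
- compound 3, `O=S(=O)(Cc1ccccc1)c1ccccc1CSc1nc2cc(Cl)ccc2[nH]1`, 24%

All three were tested in an assay on isolated protein for inhibition of Indoleamine 2,3-dioxygenase 1 (Homo sapiens), with a stated time of 60 min, tested at 10 uM; on this read-out lower numbers stand for less inhibition and higher numbers for more inhibition at the one concentration tested (going by the name of the read-out). Among them compound 1 stands highest; its nearest neighbour is compound 3, whose number lies beyond the usual scatter below it, and the furthest is compound 2, lower still and also beyond the scatter. No two of the measured compounds differ in only one place, so none of these gaps can be tied to a single structural change.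

Compound 4, `Clc1ccc2[nH]c(SCc3ccccc3CCCc3ccccc3)nc2c1`, has not yet been measured in this assay. Compared with compound 1 it carries benzyl in place of phenyl on a saturated chain carbon, two bonds along the chain from an aromatic carbon, so the chain between the two aromatic rings is one carbon longer, while the shared core of compound 1 and every other part of the molecule stay the same. The measured set gives no comparable lengthening of this chain, and the two lower compounds differ from compound 1 in other ways, so they offer no direct guide. On that basis the step of a number 7 percentage points lower from compound 1 to compound 4 (within the scatter) is expected to be small, if anything a slight drop, and possibly within the scatter. Compound 4 is therefore estimated at 40%, within a range from 20% to 60%.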

Compound 4, a percentage reported as inhibition, at one concentration (the size of the read-out at that concentration, not a potency): 19%
Compound 4: middle estimate off by 21 percentage points, on the high side; the measured number lies below the stated range.
By their numbers in this assay, from the lowest: compounds 2, 4 and 3 (each within the scatter of the next); then compound 1.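

In this assay, adding a single carbon to the chain, with benzyl in place of phenyl on a saturated chain carbon, two bonds along the chain from an aromatic carbon, gives a number 28 percentage points lower from compound 1 to compound 4 (beyond the scatter). Among the compounds shown here, this is the first comparison in the set in which only one place changes, so this gap, unlike the earlier ones, can be tied to a single structural change: going from phenethyl to 3-phenylpropyl, with the shared core untouched and no hydrogen-bond donor, hydrogen-bond acceptor or charge added, is enough to lower the read-out by more than the usual scatter. The data shown offer no explanation for this loss.

As far as these compounds go, with only these two chain lengths compared, it stays open whether a longer chain such as 4-phenylbutyl would lower the number further or whether the trend would stop there. From the compounds shown here alone, it is also open how the read-out would respond to an amine or a carboxylic acid in place of the phenyl ring at the end of the chain.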